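This account rests on a few compounds, and the source may have more. Where it says the series, first, only, none or still open, it means among the compounds named here.

Working notes on the series. All members share the core of compound 1 `CCCN1CCC(C(=O)Nc2cc(Cl)c(N)cc2OC)CC1` and differ only in the group carried on the amine nitrogen in the ring. In a functional assay on the whole organism for antagonist activity, with Mus musculus as the target (on this read-out lower numbers stand for an effect already at smaller amounts and higher numbers for an effect only at larger amounts of compound), compound 1 gives only a limit, > 10 mg/kg. Compound 2 `CCCCN1CCC(C(=O)Nc2cc(Cl)c(N)cc2OC)CC1` in this assay likewise gives only a limit, > 10 mg/kg. The difference between the two is hydrogen in place of methyl on a saturated chain carbon, three bonds along the chain from an amine nitrogen in a ring; the step in this assay is a step that the two limits leave unreadable from compound 2 to compound 1, with both values sitting at the limit of > 10 mg/kg in this assay, at which 2 of the 3 values shown sit. Going by the values given here, compound 3 `CCOc1ccc(CN2CCC(C(=O)Nc3cc(Cl)c(N)cc3OC)CC2)cc1` replaces the chain by an aromatic group, (4-ethoxyphenyl in place of propyl on a saturated chain carbon bound to an amine nitrogen in a ring); in this assay compound 3 gives 6.3 mg/kg, the only number so far. The steps of an at least 1.5-fold lower number from compound 2 to compound 3 (0.20 log units; that floor lies within the scatter) and an at least 1.5-fold lower number from compound 1 to compound 3 (0.20 log units; that floor lies within the scatter) are floors only, and each floor lies within the scatter, so no ordering of compound 3 against compound 1 or compound 2 can be claimed.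

Compound 4 `COc1ccc(CN2CCC(C(=O)Nc3cc(Cl)c(N)cc3OC)CC2)cc1` is not yet measured. It differs from compound 3 by hydrogen in place of methyl on a saturated chain carbon bound to an oxygen on an aromatic ring. This is the same kind of change as that from compound 2 to compound 1, but not the same: there the place was a saturated chain carbon three bonds along the chain from an amine nitrogen in a ring, here it is a saturated chain carbon bound to an oxygen on an aromatic ring. The earlier step, a step that the two limits leave unreadable from compound 2 to compound 1, gives no guide to size. With no readable precedent, the step from compound 3 to compound 4 is expected to be small, no change at the digits printed from compound 3 to compound 4 (within the scatter). Compound 4 is therefore estimated at 6.3 mg/kg, within a range from 3 mg/kg to 13 mg/kg. That expectation rests on the value of compound 3, 6.3 mg/kg.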

Compound 4, dose for half-maximal effect: 0.9 mg/kg
Compound 4: middle estimate off by 7.0-fold (0.85 log units), on the high side; the whole stated range lies above it.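

In this assay, hydrogen in place of methyl on a saturated chain carbon bound to an oxygen on an aromatic ring gives a 7.0-fold lower number from compound 3 to compound 4 (0.85 log units; beyond the scatter) and so this change is not silent at this place on the shared core. With the 4-methoxyphenyl group, the comparisons with the simple chains give an at least 11-fold lower number from compound 2 to compound 4 (1.04 log units; beyond the scatter) and an at least 11-fold lower number from compound 1 to compound 4 (1.04 log units; beyond the scatter), but this is a single readable case and it does not show that the size or direction of the change would carry over to another place or another core. Going by these compounds alone, the only other instance of this kind of change, on a saturated chain carbon three bonds along the chain from an amine nitrogen in a ring, cannot be read because compound 1 and compound 2 both stand only as limits: the limit of > 10 mg/kg in this assay, at which 2 of the 4 values shown sit.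

The compounds shown leave open whether the trend from ethoxy to methoxy continues when a hydroxyl, an amine or a fluorine takes the place of the methoxy group on the aromatic ring. They also leave open how a longer chain such as propoxy would read on the same core, and whether the same change would behave alike with a different amide part.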